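A few compounds are considered here, and "the series" means these few. Any claim that something is new, unique, unknown or untested is made for them only; others in the source may bear on it.

The series shares one core, carried by compound 1 `CC#C[C@H]1CN(S(=O)(=O)c2ccc(N)nc2)CCN1c1ccc([C@@](O)(CO)C(F)(F)F)cc1`, compound 2 `CC#C[C@H]1CN(S(=O)(=O)c2ccc(N)nc2)CCN1c1ccc(S(=O)(=O)NCC2CC2)cc1` and compound 3 `CC#C[C@H]1CN(S(=O)(=O)c2ccc(N)nc2)CCN1c1ccc(C(C)=O)cc1`. In an assay on cells (Hepatocyte) for inhibition of glucokinase regulatory protein (Mus musculus), with stated times of 20 min and 40 min (a higher number here means that more compound is needed for the effect, a lower number that less compound is needed), compound 1 gives 89 nM. In this assay compound 2 gives 271 nM. For compound 3 only a limit of the assay is known: in this assay compound 3 gives > 12500 nM. Compound 3 thus stands at the weak end of the numbers shown, sitting at the limit of > 12500 nM in this assay, at which 1 of the 3 values shown sits, so its true distance from the other two is open. The two steps that reach it are an at least 140-fold higher number from compound 1 to compound 3 (2.14 log units; beyond the scatter) and an at least 46-fold higher number from compound 2 to compound 3 (1.66 log units; beyond the scatter), both large. Compound 4 `CC#C[C@H]1CN(S(=O)(=O)c2ccc(N)nc2)CCN1c1ccc(S(=N)(=O)C2CC2)cc1` differs from compound 3 in that (a group of 6 heavy atoms (3 carbon, 1 nitrogen, 1 oxygen, 1 sulfur; one three-membered non-aromatic ring of carbon only) in place of a group of 3 heavy atoms (2 carbon, 1 oxygen; no ring), on an aromatic carbon); the entering group resembles the (cyclopropylmethyl)sulfamoyl of compound 2 in carrying a sulfur with a three-membered ring. Among the measured compounds shown here, the step that bears on this change most directly is the one from compound 2 to compound 3, and its reversal is expected. For compound 4 the expected step is an at least 50-fold lower number from compound 3 to compound 4 (1.69 log units; beyond the scatter), a large drop in the number toward the region of compound 2. Compound 4 is therefore estimated at 250 nM in this assay, with a range from 60 nM to 1000 nM.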

Compound 4, half-maximal effective concentration: 208 nM
For compound 4 the middle estimate is 1.2-fold (0.08 log units) above the measured one; the range from low to high includes it.
By their numbers in this assay, from the lowest: compound 1; then compounds 4 and 2 (each within the scatter of the next). At a limit, above all of these: compound 3.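

At this place, on an aromatic carbon para to a large group, a second sulfur group carrying a three-membered ring lowers the number in this assay relative to acetyl, with an at least 60-fold lower number from compound 3 to compound 4 (1.77 log units; beyond the scatter), so the recovery is no longer tied to the (cyclopropylmethyl)sulfamoyl of compound 2. The size of that step remains a bound because compound 3 stands at a limit of the assay: the limit of > 12500 nM in this assay, at which 1 of the 4 values shown sits. The smaller group of compound 4 matches that sulfamoyl, with a 1.3-fold lower number from compound 2 to compound 4 (0.11 log units; within the scatter), while a 2.3-fold higher number from compound 1 to compound 4 (0.37 log units; beyond the scatter) leaves the group of compound 1 with the lower number.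

On these data alone, whether a methyl or a longer chain in place of the cyclopropyl on the sulfur keeps the number in this assay remains open. So does the effect of a plain methylsulfonyl group at this place.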